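Methoxymethyl capping of a second ring nitrogen in a uracil-type series

The compounds below may be only part of what the source reports. "The series", "measured", "known", "first", "only" and "open" are said of these compounds alone.

Compound 1 `O=c1cc(CC(O)(COCc2ccccc2)COCc2ccccc2)[nH]c(=O)[nH]1` and compound 2 `COCn1c(CC(O)(COCc2ccccc2)COCc2ccccc2)cc(=O)[nH]c1=O` share one core; compound 3 `COCn1c(=O)[nH]c(CC(COCc2ccccc2)COCc2ccccc2)c(C)c1=O` and compound 4 `COCn1c(CC(COCc2ccccc2)COCc2ccccc2)c(C)c(=O)n(COC)c1=O` share another, and the difference between the two cores is not broken down here. All are characterised in a functional assay on HeLa cells (Homo sapiens) for antiproliferative activity, read by MTT assay, with a stated time of 72 h; on this read-out lower numbers stand for stronger inhibition and higher numbers for weaker inhibition. Compound 1 gives only a limit, > 100000 nM. Compound 2 likewise gives only a limit, > 100000 nM. For the measured compounds named here, compound 3 gives the one number of the set, 17000 nM.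

The change from compound 1 to compound 2 is methoxymethyl in place of hydrogen on an aromatic nitrogen; the step that the two limits leave unreadable from compound 1 to compound 2, because the limit of > 100000 nM in this assay, at which 2 of the 3 values shown sit, covers both ends. The change from compound 3 to compound 4 is the same kind of change, (methoxymethyl in place of hydrogen on an aromatic nitrogen), differing in its surroundings: here the place is also meta to a methoxymethyl group (3 heavy atoms) and meta to a methyl group (1 heavy atom).

For compound 4 the measured precedent gives no usable size, since the step that the two limits leave unreadable from compound 1 to compound 2 cannot be read; the expectation therefore rests on compound 3 at 17000 nM with the step of a 1.2-fold higher number from compound 3 to compound 4 (0.07 log units; within the scatter) expected to stay within the usual scatter. Compound 4 is accordingly expected to give about 20000 nM in this assay. For compound 4 the range is estimated from 6000 nM to 100000 nM, with a real chance that only a limit is reported.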

Compound 4, half-maximal inhibitory concentration: 300 nM
The estimate for compound 4 lay 67-fold (1.82 log units) above the measured number, and the stated range ends above it.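

In this assay, methoxymethyl in place of hydrogen on an aromatic nitrogen gives a 57-fold lower number from compound 3 to compound 4 (1.75 log units; beyond the scatter), a large step towards stronger inhibition on the core shared by these two compounds. The same change on the core of compound 1 offers no size for comparison, and the step from compound 1 to compound 2 cannot be read because both values are the same assay limit: the limit of > 100000 nM in this assay, at which 2 of the 4 values shown sit. The series therefore shows that this change can matter strongly where the place is meta to a methoxymethyl group and meta to a methyl group, but it does not show that the effect carries over from one core to the other, and this single readable pair assigns it no cause.

For the compounds shown here, compound 4 carries two methoxymethyl groups, so it remains open what the newly added group would do on this core without the one already present in compound 3, and which of the differences between the two cores, the hydroxyl on the side chain or the methyl on the ring, governs the outcome. On these data alone, it also remains open whether a longer chain, such as ethoxymethyl, or a chain ending in an amine would be tolerated on the same nitrogen.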